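The compounds below may be only part of what the source reports. "The series", "measured", "known", "first", "only" and "open" are said of these compounds alone.

Compound 1 `Fc1ccc(Nc2nc(-c3cccc(F)c3)nc3ccc(F)cc23)cc1`: > 50000 nM
Compound 2 `Fc1cccc(-c2nc(Nc3ccc(Br)cc3)c3cc(F)ccc3n2)c1`: > 50000 nM

Both compounds were tested in a functional assay on U2OS cells (Homo sapiens) for cytotoxicity, read by MTT assay, with a stated time of 48 h; on this read-out lower numbers stand for stronger inhibition and higher numbers for weaker inhibition. In this assay compound 1 gives > 50000 nM, which is a limit of the assay rather than a number. In this assay compound 2 gives > 50000 nM, again only a limit. The step that the two limits leave unreadable from compound 1 to compound 2 is therefore not readable, since both values sit at the limit of > 50000 nM in this assay, at which 2 of the 2 values shown sit. Compound 2 thus stands at the limit, with no number of its own to anchor a comparison.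

Compound 3 `Nc1cccc(Nc2nc(-c3cccc(F)c3)nc3ccc(F)cc23)c1` differs from compound 2 by 3-aminophenyl in place of 4-bromophenyl on a nitrogen on an aromatic ring. Within the data shown here, no measured step bears on this particular change, and the single recorded step has no readable size. The step of a number no higher from compound 2 to compound 3 (the limit leaves the size open) is therefore expected to stay within the scatter. Compound 3 is expected to remain at or near the limit, estimated at 50000 nM, within 15000 nM and 200000 nM.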

Compound 3, half-maximal inhibitory concentration: 49700 nM
Estimate against measurement, compound 3: 1.0-fold (0.00 log units) above, within the range that was stated.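

In this assay compound 3 gives 49700 nM, the only actual number among the compounds shown, so this place on the nitrogen now carries a group, 3-aminophenyl, with a value of its own. Compound 2 gives > 50000 nM, which is a limit of the assay and not a number. The step of a number no higher from compound 2 to compound 3 (the limit leaves the size open) and the step of a number no higher from compound 1 to compound 3 (the limit leaves the size open) cannot be read, so the change to 3-aminophenyl has no measurable size here, and the only firm reference for it is a limit: the limit of > 50000 nM in this assay, at which 2 of the 3 values shown sit.

As far as these compounds go, whether 4-aminophenyl on the same nitrogen, or a carboxylic acid in place of the amine, would give a readable number stays open. Also open, from the compounds shown here alone, is whether any group at this place can bring the value clearly under the limit.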